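This account rests on a few compounds, and the source may have more. Where it says the series, first, only, none or still open, it means among the compounds named here.

Measured compounds:
- compound 1 `CCCCCC(=O)Nc1ccc2[nH]cc(C3CCN(C)CC3)c2n1`, an assay for binding affinity to 5-hydroxytryptamine receptor 1F (Homo sapiens), read by radioligand binding; a higher number here means a weaker inhibitor, a lower number a stronger inhibitor: 13 nM
- compound 2 `CN1CCC(c2c[nH]c3ccc(NC(=O)C4CCCCC4)nc23)CC1`, this assay: 20 nM

Among the measured compounds shown here, compound 2 gives the higher of the two numbers so far, with compound 1 as its only neighbour; the gap a 1.5-fold higher number from compound 1 to compound 2 (0.19 log units; within the scatter) lies within the scatter, so the two compounds cannot be told apart on these figures, and the shared core carries either a pentyl or a cyclohexyl group on the carbonyl carbon without a resolvable difference.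

Compound 3 `CN1CCC(c2c[nH]c3ccc(NC(=O)c4cccc(F)c4)nc23)CC1` is not yet measured. It differs from compound 2 in one place: 3-fluorophenyl in place of cyclohexyl on a carbonyl carbon. For the measured compounds named here, the only step recorded, pentyl to cyclohexyl on the same carbonyl carbon, was a 1.5-fold higher number from compound 1 to compound 2 (0.19 log units; within the scatter), and it does not involve an aromatic group, so it bears on the present change only in showing that the carbonyl substituent has so far been tolerant of exchange. Going by the values given here, no step from a saturated ring to a 3-fluorophenyl group exists in this set.

Compound 3 is therefore expected to stay close to compound 2, with the estimated step of a 1.3-fold higher number from compound 2 to compound 3 (0.10 log units; within the scatter) kept small and its direction uncertain. The estimate for compound 3 in this assay is 25 nM, within a range from 8 nM to 80 nM.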

Compound 3, inhibition constant: 11 nM
For compound 3 the middle estimate is 2.3-fold (0.36 log units) above the measured one; the range from low to high includes it.
By their numbers in this assay, from the lowest: compounds 3, 1 and 2 (each within the scatter of the next).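

In this assay, a six-membered aromatic ring bearing fluorine can stand on the carbonyl carbon of the amide without a resolvable difference from a saturated ring or an open chain: the change from cyclohexyl to 3-fluorophenyl gives a 1.8-fold lower number from compound 2 to compound 3 (0.26 log units; within the scatter) and the change from pentyl to 3-fluorophenyl gives a 1.2-fold lower number from compound 1 to compound 3 (0.07 log units; within the scatter) on the same shared core. The three compounds now span an open chain, a saturated ring and an aromatic ring at this one place, and their numbers cannot be told apart, so neither aromatic character nor the added fluorine has a readable effect on these figures. No supporting data on the cause of this flat result are available here.

Going by these compounds, what the fluorine contributes remains open, and a plain phenyl group on the carbonyl carbon would be the direct comparison with compound 3. On these data alone, it is also open whether this flat picture in this assay extends to substituents carrying an amine or a carboxylic acid, or to a much longer chain.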